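Chloro for Methoxy: Expected Effect on Cell Growth Inhibition

This account rests on a few compounds, and the source may have more. Where it says the series, first, only, none or still open, it means among the compounds named here.

Two compounds have been measured in an ADME assay on 184B5 cells (Homo sapiens) for cytotoxicity, read by MTT assay, with a stated time of 72 h; on this read-out lower numbers stand for stronger inhibition of growth and higher numbers for weaker inhibition of growth:

compound 1, `COc1ccc(OC(=O)Nc2ccc([Se]C#N)cc2)cc1`, gives 4500 nM
compound 2, `CC(C)COC(=O)Nc1ccc([Se]C#N)cc1`, gives 5800 nM

Compound 1 holds the lower of the two numbers in this assay, but compound 2 lies within the usual scatter of it, so the two cannot be told apart on these data. Going by the values given here, no pair among the measured compounds differs in a single place, so no step of any kind is known here.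

Compound 3, `N#C[Se]c1ccc(NC(=O)Oc2ccc(Cl)cc2)cc1`, is the next compound to be measured. It differs from compound 1 by a single exchange: chloro in place of methoxy on an aromatic carbon. Among the compounds with values here, nothing among the measured compounds shows what such an exchange does in this assay. With only compound 1 as a reference, the step of a 1.1-fold lower number from compound 1 to compound 3 (0.03 log units; within the scatter) is expected to stay within the scatter, in no firm direction. Compound 3 is therefore estimated at 4200 nM, with a range from 1800 nM to 9500 nM.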

Compound 3, concentration for 50% growth inhibition: 5600 nM
Compound 3: middle estimate off by 1.3-fold (0.12 log units), on the low side; the range from low to high includes it.
By their numbers in this assay, from the lowest: compounds 1, 3 and 2 (each within the scatter of the next).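

In this assay, chloro in place of methoxy on an aromatic carbon, para to a large group, gives a 1.2-fold higher number from compound 1 to compound 3 (0.09 log units; within the scatter) and so leaves the two compounds indistinguishable. Going by these compounds alone, this is the first single-place exchange available, and it shows that the methoxy group of compound 1 can give way to chloro at this position without a change that can be read on these data. No measurement at hand accounts for this result.

The compounds shown leave open whether any other group here, such as an amine, a carboxylic acid or a longer alkoxy chain, would move the number beyond the scatter of compound 1. They also leave open whether chloro in place of methoxy would have the same outcome on a different core.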